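Trifluoromethyl in place of 4-fluorophenyl: an untested step

The compounds below may be only part of what the source reports. "The series", "measured", "known", "first", "only" and "open" are said of these compounds alone.

Compound 1, `Cc1n[nH]c(C(=O)O)c1Cc1ccccc1-c1ccc(F)cc1`: 11%
Compound 2, `Cc1n[nH]c(C(=O)O)c1Cc1cccc(-c2ccc(C(N)=O)cc2)c1`: 18%

Both numbers come from an assay on isolated protein for inhibition of 2-Hydroxyacid oxidase 2 (Homo sapiens), tested at 1 uM; a lower number here means a weaker effect, a higher number a stronger effect of the compound at the concentration tested. Compound 1 stands at the low end of the two values, but its distance from compound 2 lies within the usual scatter of this assay, so the two compounds cannot be told apart on these data; both show only a weak effect at the concentration tested.

Compound 3, `Cc1n[nH]c(C(=O)O)c1Cc1ccccc1C(F)(F)F`, has not yet been measured. It differs from compound 1 in one place: trifluoromethyl in place of 4-fluorophenyl on an aromatic carbon. For the measured compounds named here, no measured pair with a change of this kind is available, so nothing measured shows how large such a step tends to be. With both measured compounds weak in this assay, the expected step from compound 1 to compound 3 is a number 1 percentage points lower from compound 1 to compound 3 (within the scatter), that is, no change beyond the scatter. Compound 3 is therefore expected to give about 10%, with a range from 0% to 25%.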

Compound 3, a percentage reported as inhibition, at one concentration (the size of the read-out at that concentration, not a potency): 13%
Estimate against measurement, compound 3: 3 percentage points below; the measured number falls inside the stated range.
By their numbers in this assay, from the lowest: compounds 1, 3 and 2 (each within the scatter of the next).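

In this assay, putting trifluoromethyl in place of 4-fluorophenyl on this aromatic carbon gives a number 2 percentage points higher from compound 1 to compound 3 (within the scatter) and so makes no measurable difference. The whole six-membered aromatic ring can therefore go from this position, leaving a group with fewer heavy atoms and no ring, and the read-out stays weak. For the compounds shown here, with both compounds this low, the step shows only that neither group gives a strong effect at the concentration tested, and no other measurement here helps to explain the result.

As far as these compounds go, what remains open is whether any group on this carbon can raise the read-out well beyond the scatter, since both groups compared here are uncharged and carry no hydrogen-bond donors or acceptors. An amine, a carboxylic acid or a longer chain at this position would test that question directly.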